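From 3-Bromophenyl to 2,3,4-Trimethoxyphenyl in a Cell Assay

The compounds below may be only part of what the source reports. "The series", "measured", "known", "first", "only" and "open" are said of these compounds alone.

In a functional assay on PC-3 cells (Homo sapiens) for cytotoxicity, read by MTT assay, with a stated time of 72 h (a higher number here means a weaker inhibitor, a lower number a stronger inhibitor), compound 1 `O=C(N/N=C/c1cccc(Br)c1)Nc1cc2c(Nc3ccc(F)c(Cl)c3)ncnc2cc1O[C@H]1CCOC1` gives 15500 nM as the lowest of three measured numbers, which makes it the strongest so far. Compound 2 `O=C(N/N=C/c1ccc([N+](=O)[O-])cc1)Nc1cc2c(Nc3ccc(F)c(Cl)c3)ncnc2cc1O[C@H]1CCOC1` gives 33500 nM and compound 3 `COc1ccc(/C=N/NC(=O)Nc2cc3c(Nc4ccc(F)c(Cl)c4)ncnc3cc2O[C@H]2CCOC2)cc1` gives 34100 nM. Compound 4 `COc1ccc(/C=N/NC(=O)Nc2cc3c(Nc4ccc(F)c(Cl)c4)ncnc3cc2O[C@H]2CCOC2)c(OC)c1OC` awaits measurement and differs from compound 1 in one place: 2,3,4-trimethoxyphenyl in place of 3-bromophenyl on a carbon with a double bond to nitrogen. Two measured swaps of the same 3-bromophenyl group bear on this change: a 2.2-fold higher number from compound 1 to compound 2 (0.33 log units; beyond the scatter) and a 2.2-fold higher number from compound 1 to compound 3 (0.34 log units; beyond the scatter). Both were modest rises, and compound 3 is the closest match with its 4-methoxyphenyl group, so a similar modest rise is expected in this assay. The estimated step is a 1.9-fold higher number from compound 1 to compound 4 (0.29 log units; within the scatter). For compound 4 the expected value is 30000 nM within a range of 14000 nM to 65000 nM.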

Compound 4, half-maximal inhibitory concentration: 25600 nM
Compound 4: middle estimate off by 1.2-fold (0.07 log units), on the high side, within the range that was stated.
By their numbers in this assay, from the lowest: compounds 1, 4, 2 and 3 (each within the scatter of the next, the first and the last beyond it).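

In this assay the swap of 3-bromophenyl for 2,3,4-trimethoxyphenyl gives a 1.7-fold higher number from compound 1 to compound 4 (0.22 log units; within the scatter) and so, unlike the two earlier swaps of that group, stays within the scatter. The new group also cannot be separated from 4-methoxyphenyl, with a 1.3-fold lower number from compound 3 to compound 4 (0.12 log units; within the scatter) here, or from 4-nitrophenyl, with a 1.3-fold lower number from compound 2 to compound 4 (0.12 log units; within the scatter) here, even though it brings three hydrogen-bond acceptors to this position. No measurement shown explains these results. Going by these compounds, it remains open whether an amine or a carboxylic acid on this aromatic ring would move the number beyond the scatter.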